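The source may hold more compounds than are shown below. What is called first, only, known or untested is meant among the compounds shown, and "the series" means these compounds.

Compound 3, `Cc1nc(N)sc1CCCN/C(N)=N/C(=O)NC(C)c1ccc(OC(F)(F)F)cc1`, sits at the bottom of the three compounds measured in a functional assay on Right cardiac atrium for agonist activity at histamine H2 receptor (Cavia porcellus), with a stated time of 30 min, in the presence of a further agent that is not named here; on this read-out higher numbers stand for larger maximal responses and lower numbers for smaller maximal responses: compound 3 gives 0.61. Its nearest neighbour is compound 2, `Cc1nc(N)sc1CCCN/C(N)=N/C(=S)N[C@H](C)c1ccccc1`, which in this assay reaches 0.87, a gap beyond the usual scatter. Furthest away is compound 1, `Cc1nc(N)sc1CCCN/C(N)=N/C(=O)NC(c1ccccc1)C(C)C`, which in this assay reaches 1.04, again well beyond the scatter. No two of these compounds differ in only one place, so no single structural step among them can be read on its own.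

Compound 4, `Cc1nc(N)sc1CCCN/C(N)=N/C(=O)NC(C)c1ccc(F)cc1`, is not yet measured. It departs from compound 3 in one way: fluoro in place of trifluoromethoxy on an aromatic carbon. Compound 1 carries no substituent on its phenyl ring and gives the highest value, whereas compound 3 with trifluoromethoxy gives the lowest, so the move to a smaller fluoro group is expected to raise the response; the step from compound 3 to compound 4 in this assay is estimated at a number 0.19 higher from compound 3 to compound 4 (beyond the scatter), beyond the scatter but short of compound 1. Compound 4 is therefore expected to give 0.8 in this assay, within a range from 0.62 to 0.98.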

Compound 4, intrinsic activity: the largest response reached, as a fraction of the reference agonist's: 0.92
Compound 4: the middle estimate sits 0.12 below what was measured; the range from low to high includes it.
By their numbers in this assay, from the lowest: compound 3; then compounds 2 and 4 (each within the scatter of the next); then compound 1.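

In this assay the maximal response comes out a number 0.31 higher from compound 3 to compound 4 (beyond the scatter) when fluoro replaces trifluoromethoxy on the aromatic carbon, with the rest of the molecule unchanged. Among the compounds shown here, this gives the first comparison in the set that can be read at a single place, and it shows that the group on this carbon alone can shift the response by a large step. Nothing available here accounts for that shift.

As far as these compounds go, with only these two groups compared at this position, no trend can be drawn, and what chloro, methoxy or an amine on the same carbon would give remains open. From the compounds shown here alone, it is also open whether the same exchange would produce a similar step in a compound with a thiocarbonyl in place of the carbonyl.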